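A few compounds are considered here, and "the series" means these few. Any claim that something is new, unique, unknown or untested is made for them only; others in the source may bear on it.

Measured compounds:
compound 1 `COC(=O)c1ccc2ccc(C(=O)c3ccc(C(F)(F)F)cc3)c-2cc1` — -47.4%
compound 2 `O=C(O)c1ccc2ccc(C(=O)c3ccc(C(F)(F)F)cc3)c-2cc1` — 1%
compound 3 `COC(=O)c1ccc2c(C(=O)c3ccccc3)cc(C(=O)c3ccccc3)c-2cc1` — -14.5%

In an assay on cells for displacement of a labelled ligand from Orexin receptor type 2 (Homo sapiens), read by scintillation counting, with stated times of 10 min and 90 min, tested at 10 uM (on this read-out lower numbers stand for less inhibition and higher numbers for more inhibition at the one concentration tested (going by the name of the read-out)), compound 1 gives -47.4%, and compound 2 gives 1%. The two differ by one change, (hydrogen in place of methyl on an oxygen next to a carbonyl group), and this change made a step of a number 48.4 percentage points higher from compound 1 to compound 2 (beyond the scatter). Compound 3 gives -14.5% in this assay; its difference from compound 1 lies in the core, and the difference between the two cores is not broken down here. Compound 4 `O=C(O)c1ccc2c(C(=O)c3ccccc3)cc(C(=O)c3ccccc3)c-2cc1` has not been measured yet. For the measured compounds named here, it differs from compound 3 by hydrogen in place of methyl on an oxygen next to a carbonyl group, which is the same change as the one from compound 1 to compound 2, at a place described in the same words. Going by the values given here, the only precedent for this change is the step from compound 1 to compound 2, made on a different core, so the expectation for compound 4 rests on that single step. Compound 4 is expected to reach about 15% in this assay, within a range from -10% to 40%. This estimate means a step of a number 29.5 percentage points higher from compound 3 to compound 4 (beyond the scatter), somewhat smaller than the earlier one, allowing for the core being different.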

Compound 4, a percentage reported as inhibition, at one concentration (the size of the read-out at that concentration, not a potency): 27%
Estimate against measurement, compound 4: 12 percentage points below; low and high end bracket the measured number.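

In this assay, hydrogen in place of methyl on an oxygen next to a carbonyl group again gave a large step, a number 41.5 percentage points higher from compound 3 to compound 4 (beyond the scatter). Set beside the earlier case, the change carried over from the core of compound 1 to the core of compound 3 with a step of much the same size: the same change on two cores in this assay, a number 48.4 percentage points higher (beyond the scatter) from compound 1 to compound 2 and a number 41.5 percentage points higher (beyond the scatter) from compound 3 to compound 4, 6.9 percentage points apart, within the scatter of two such steps. This shows that, on these two cores and at the one concentration tested, the methoxycarbonyl to carboxy change moved the read-out in the same direction by a comparable amount, but it does not show that the step would hold on any further core, and it gives no reason for the step or any measure of potency.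

The compounds shown leave open whether an amide or a sulfonamide in place of the carboxylic acid would give a step of similar size. They also leave open where a longer ester, such as an ethyl ester, would fall relative to the methyl esters on either core.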